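A few compounds are considered here, and "the series" means these few. Any claim that something is new, unique, unknown or untested is made for them only; others in the source may bear on it.

Compound 1 `Fc1cc(Nc2cc(Nc3cccc(Cl)c3)ncn2)ccc1Oc1ccncc1-c1cccnc1` gives 90 nM in a functional assay on MDA-MB-231 cells (Homo sapiens) for cytotoxicity, read by MTT assay, with a stated time of 72 h; a higher number here means a weaker inhibitor, a lower number a stronger inhibitor. Compound 2 `COc1cc(Nc2cc(Nc3ccc(Oc4ccncc4-c4cccnc4)c(F)c3)ncn2)cc(OC)c1` gives 4240 nM. Compound 3 `Cn1c(=O)c(C(=O)Nc2ccc(Oc3ccncc3-c3cccnc3)c(F)c2)nn(-c2cccc(C(F)(F)F)c2)c1=O` gives 3980 nM.

Compound 3 stands second highest of the three numbers. Its nearest neighbour is compound 2, and the two values are within the scatter of each other, so they cannot be told apart; compound 1 lies far lower, beyond the scatter, and is the strongest inhibitor of the set.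

Compound 4 `Cn1c(=O)c(C(=O)Nc2ccc(Oc3ccncc3-c3cccnc3)c(F)c2)nn(-c2ccc(F)c(Cl)c2)c1=O` has not yet been measured. It differs from compound 3 in one place: 3-chloro-4-fluorophenyl in place of 3-(trifluoromethyl)phenyl on an aromatic nitrogen.

Within the data shown here, only one measured step exists, a 47-fold higher number from compound 1 to compound 2 (1.67 log units; beyond the scatter), and it sits on a different core, where the aryl group on a nitrogen was changed from a 3-chlorophenyl to a 3,5-dimethoxyphenyl. It shows that swapping the aryl on a nitrogen can move the number a great deal, but it does not tell how a 3-chloro-4-fluorophenyl compares with a 3-(trifluoromethyl)phenyl on the core of compound 3. The change keeps the ring size, the count of donors and acceptors and the absence of charge. The expected step is therefore small, a 1.6-fold lower number from compound 3 to compound 4 (0.20 log units; within the scatter), and may stay within the scatter. Compound 4 is expected to give about 2500 nM, between 800 nM and 8000 nM.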

Compound 4, half-maximal inhibitory concentration: 11300 nM
Compound 4: the middle estimate sits 4.5-fold (0.66 log units) below what was measured, outside the stated range (above it).
By their numbers in this assay, from the lowest: compound 1; then compounds 3 and 2 (each within the scatter of the next); then compound 4.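

On the aromatic nitrogen of the core of compound 3, the choice of aryl group matters in this assay, and exchanging 3-(trifluoromethyl)phenyl for 3-chloro-4-fluorophenyl gives a 2.8-fold higher number from compound 3 to compound 4 (0.45 log units; beyond the scatter). This modest step lies beyond the scatter, even though both groups have one six-membered aromatic ring of carbon only, no hydrogen-bond donors or acceptors, and no net charge, so those shared counts alone do not fix the number at this position. Nothing measured here explains the rise, and the result stands as an observation without a known cause.

As far as these compounds go, the two groups differ in more than one feature, so it remains open whether the trifluoromethyl group, the chlorine or the fluorine accounts for the step. From the compounds shown here alone, it is also open how far the number would move with an amine or a carboxylic acid on this aryl ring, or with a longer chain in place of the ring on this nitrogen.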